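The source may report more compounds than this note shows. Statements on the series, on what has been measured and on what is new or still open speak of the compounds shown alone.

Measured so far in a physicochemical assay for lipophilicity, using the shake flask method, in phosphate buffer, measured as octanol-water partition, with a stated time of 24 h, at pH 7.4; a lower number here means a more polar compound, a higher number a more lipophilic compound:
- compound 1 `Cc1cc(C2CS(=O)(=O)Oc3c2c(C2CC2)nn3-c2ccccc2Cl)ccc1Br`: 2.53
- compound 2 `Cc1nn(-c2ccccc2F)c2c1C(c1ccc(F)cc1)CS(=O)(=O)O2`: 2.13

Compound 1 stands highest of these two numbers, and compound 2 lies lower by a gap beyond the usual scatter. Among the compounds with values here, compound 3 `O=S1(=O)CC(c2ccc(F)cc2)c2c(C3CC3)nn(-c3ccccc3Cl)c2O1` has no measurement yet in this assay. It differs from compound 1 in one place, with 4-fluorophenyl in place of 4-bromo-3-methylphenyl on a saturated ring carbon. The rest of the core of compound 1 is kept.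

Within the data shown here, no two measured compounds differ in one place only, so the series offers no direct guide to the size of this change. Compound 1 stands at 2.53. A fall beyond the scatter is expected from compound 1, although this expectation rests on the structural change alone. The expected change is a number 0.33 log units lower from compound 1 to compound 3 (beyond the scatter). Compound 3 is expected at 2.2, with an estimated range from 1.85 to 2.55.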

Compound 3, partition coefficient: 2.04
Compound 3: middle estimate off by 0.16 log units, on the high side, within the range that was stated.
By their numbers in this assay, from the lowest: compounds 3 and 2 (each within the scatter of the next); then compound 1.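

In this assay, within the data shown here, 4-fluorophenyl in place of 4-bromo-3-methylphenyl on a saturated ring carbon gives a number 0.49 log units lower from compound 1 to compound 3 (beyond the scatter), the first one-place step and so the first direct reading of this position. The rest of the core of compound 1 is kept, and both groups are a six-membered aromatic ring of carbon only, with no hydrogen-bond donors or acceptors and no net charge, so the read-out moves at this position with those features unchanged. No measured data bear on the origin of this step.

Bromine, the methyl group and fluorine all change in this one step, so the share of each in the size of the step remains unresolved. Also open, as far as these compounds go, is how the partition coefficient responds at this saturated ring carbon to a group of a different kind, such as an amine or a carboxylic acid, in place of the substituted phenyl rings seen so far.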